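The source may report more compounds than this note shows. Statements on the series, on what has been measured and on what is new or still open speak of the compounds shown alone.

Series notes. Compound 2 `COc1ccc(-c2cc(N3CCC(CCNS(N)(=O)=O)CC3)ncn2)cc1` carries a 4-methoxyphenyl group and a two-carbon chain to the sulfamide; compound 1 `NS(=O)(=O)NCC1CCN(c2cc(-c3cccc(Cl)c3)ncn2)CC1` carries a 3-chlorophenyl group. Within the data shown here, in a functional assay on HT-29 cells (Homo sapiens) for antiproliferative activity, read by sulforhodamine B assay, with a stated time of 48 h (a higher number here means a weaker inhibitor of growth, a lower number a stronger inhibitor of growth), compound 2 gives 72300 nM, the higher of the two numbers so far, and compound 1 gives 47500 nM; the two values lie within the scatter of each other, so the two compounds are not separated on the numbers available. Compound 3 `NS(=O)(=O)NCCC1CCN(c2cc(-c3cccc(Cl)c3)ncn2)CC1` is not yet measured. Relative to compound 2 the change is 3-chlorophenyl in place of 4-methoxyphenyl on an aromatic carbon. Among the measured compounds shown here, no measured pair isolates this exchange, and the only other compound, compound 1, differs in more than one place, so the size of the step is open. The expectation for a 1.4-fold lower number from compound 2 to compound 3 (0.16 log units; within the scatter) is a step of no more than the usual scatter, in either direction. Compound 3 is estimated at 50000 nM, with a range from 20000 nM to 120000 nM.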

Compound 3, concentration for 50% growth inhibition: 31600 nM
Compound 3: middle estimate off by 1.6-fold (0.20 log units), on the high side, within the range that was stated.
By their numbers in this assay, from the lowest: compounds 3, 1 and 2 (each within the scatter of the next, the first and the last beyond it).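

In this assay, among these compounds, 3-chlorophenyl in place of 4-methoxyphenyl on the aromatic carbon gives a 2.3-fold lower number from compound 2 to compound 3 (0.36 log units; beyond the scatter), the first reading of this exchange in a pair differing in one place, and it shows that the position responds modestly to the change. With 3-chlorophenyl held constant, (sulfamoylamino)methyl in place of sulfamoylamino on the saturated chain carbon gives a 1.5-fold lower number from compound 1 to compound 3 (0.18 log units; within the scatter), so these two chain lengths are not separated. Nothing available accounts for either step.

The aryl exchange changes both the group on the phenyl ring and where it sits, so 4-chlorophenyl or 3-methoxyphenyl would be needed to tell those two apart. On these data alone, whether a longer chain, or an amine in place of the sulfamide, would shift growth inhibition remains open.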